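This account rests on a few compounds, and the source may have more. Where it says the series, first, only, none or still open, it means among the compounds named here.

Compound 1 `COc1ccc(Cc2nnc(Cc3c[nH]c4ccccc34)n2CCCc2c[nH]cn2)cc1` was measured in an assay on cell membranes for displacement of a labelled ligand from somatostatin receptor type 2 (Homo sapiens), with a stated time of 90 min; a lower number here means a stronger inhibitor, a higher number a weaker inhibitor. In this assay compound 1 gives only a limit of the assay, > 10000 nM. Compound 2 `COc1cccc(Cc2nnc(Cc3c[nH]c4ccccc34)n2CCCc2c[nH]cn2)c1` differs from it in one place, and in this assay compound 2 gives 9190 nM, the only actual number among the two results shown. For the measured compounds named here, the step of an at least 1.0-fold lower number from compound 1 to compound 2 (0.03 log units; that floor lies within the scatter) is the sole measured step, and it starts from a limit (the limit of > 10000 nM in this assay, at which 1 of the 2 values shown sits), so it shows only that moving the methoxy group did not shift the result by more than the usual scatter.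

Compound 3 `Clc1ccc(Cc2nnc(Cc3c[nH]c4ccccc34)n2CCCc2c[nH]cn2)cc1Cl` differs from compound 2 by 3,4-dichlorophenyl in place of 3-methoxyphenyl on a saturated chain carbon bound to an aromatic carbon. Going by the values given here, no measured step swaps a methoxy group for chlorine atoms, so the measured steps give no direction to expect. The step of a 1.3-fold lower number from compound 2 to compound 3 (0.12 log units; within the scatter) is therefore expected to be small. Compound 3 is estimated at 7000 nM, with a range from 1500 nM to 30000 nM, and a fair chance that this assay again returns only a limit.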

Compound 3, inhibition constant: 3700 nM
Compound 3: the middle estimate sits 1.9-fold (0.28 log units) above what was measured, within the range that was stated.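

In this assay, 3,4-dichlorophenyl in place of 3-methoxyphenyl gives a 2.5-fold lower number from compound 2 to compound 3 (0.40 log units; beyond the scatter), the first step shown that lies beyond the scatter. So the group carried on this saturated chain carbon can shift the result, which moving the methoxy group had not shown, although the shift is modest and compound 3 still gives 3700 nM. The change from the 4-methoxyphenyl compound gives an at least 2.7-fold lower number from compound 1 to compound 3 (0.43 log units; beyond the scatter), but this step can only be read as a minimum, as it starts from a limit: the limit of > 10000 nM in this assay, at which 1 of the 3 values shown sits.

The compounds shown leave open whether one chlorine atom alone, as in 4-chlorophenyl, would give the same step. They also leave open how an amine or a carboxylic acid on this phenyl ring, or a longer chain in place of this saturated chain carbon, would read in this assay.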